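A methyl on the ring amine: compound 3 to compound 4

This account rests on a few compounds, and the source may have more. Where it says the series, first, only, none or still open, it means among the compounds named here.

compound 1, `O=C([C@@H]1CCCN1)N1CCN(Cc2ccccn2)CC1` — in an assay on membranes from striatum for binding affinity to Neuronal acetylcholine receptor; alpha4/beta2 (Rattus norvegicus) (a lower number here means a stronger inhibitor, a higher number a weaker inhibitor), compound 1 gives a limit of the assay, > 100000 nM
compound 2, `O=C(C1CCCCN1)N1CCN(Cc2ccccn2)CC1` — in this assay compound 2 gives a limit of the assay, > 100000 nM
compound 3, `c1cc(CN2CCN(C[C@@H]3CCCN3)CC2)ccn1` — in this assay compound 3 gives 46000 nM

Among the compounds with values here, compound 3 stands as the only compound of the three with a number in this assay; the other two values are limits. Within the data shown here, the single step among the measured compounds, a step that the two limits leave unreadable from compound 1 to compound 2, has no readable size because the limit of > 100000 nM in this assay, at which 2 of the 3 values shown sit, holds both of its ends.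

Compound 4, `CN1CCC[C@H]1CN1CCN(Cc2ccncc2)CC1`, differs from compound 3 in one place: methyl in place of hydrogen on an amine nitrogen in a ring. Among the measured compounds shown here, none of the measured steps touches this amine nitrogen, and the one step that was measured gives no size at all, so there is nothing to set a direction for the change from compound 3 to compound 4. The expectation therefore rests on compound 3 alone, and the step is expected to stay within the usual scatter, as a 1.2-fold lower number from compound 3 to compound 4 (0.06 log units; within the scatter). For compound 4 the estimated value in this assay is 40000 nM, with a range from 10000 nM to 150000 nM, and a real chance that the assay again reports only a limit rather than a number.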

Compound 4, inhibition constant: 38900 nM
For compound 4 the middle estimate is 1.0-fold (0.01 log units) above the measured one; the range from low to high includes it.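

In this assay, methyl in place of hydrogen on the amine nitrogen of the five-membered ring gives a 1.2-fold lower number from compound 3 to compound 4 (0.07 log units; within the scatter). The methyl sits next to the ring atom that bears a large group, and this position accepts it without a change that can be told from the scatter, so the hydrogen on this amine is not required for the affinity that compound 3 shows. Within the data shown here, this is also the first step whose size can be read, since it joins two numbers and not two limits: the limit of > 100000 nM in this assay, at which 2 of the 4 values shown sit.

The compounds shown leave open whether a longer chain on this nitrogen, such as ethyl or propyl, or a benzyl group would be accepted as the methyl is, or whether a step beyond the scatter would appear. They also leave open whether the same methyl would have any readable effect on the carbonyl-linked pyrrolidin-2-yl of compound 1, and whether any change at this nitrogen can move the series far from the values of compound 3 and compound 4.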